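The compounds below may be only part of what the source reports. "The series", "measured", "known", "first", "only" and "open" are said of these compounds alone.

In a functional assay on MCF7 cells (Homo sapiens) for antiproliferative activity, read by sulforhodamine B assay, with a stated time of 48 h (a higher number here means a weaker inhibitor, a lower number a stronger inhibitor), compound 1 `CCc1ccccc1NS(=O)(=O)c1ccc(N2CCNC2=O)cc1` gives 350 nM, the higher of the two exact numbers in this small series. Compound 2 `O=C1NCCN1c1ccc(S(=O)(=O)Nc2ccc3[nH]ccc3c2)cc1` gives 170 nM, a gap just beyond the scatter. In this assay compound 3 `O=C1NCCN1c1ccc(S(=O)(=O)Nc2ccc(C3CCCCC3)cc2)cc1` reads > 1000 nM, which is a limit and not a number. Compound 4 `Cc1cccc(NS(=O)(=O)c2ccc(N3CCNC3=O)cc2)c1` has 3-methylphenyl in place of 2-ethylphenyl on a sulfonamide nitrogen. Going by the values given here, no measured pair isolates this change, so the expectation is anchored on compound 1 at 350 nM. The expected change in this assay stays within the scatter, with a slight lean towards a higher number: a 1.3-fold higher number from compound 1 to compound 4 (0.11 log units; within the scatter). For compound 4 the estimated value is 450 nM, with an expected range of 150 nM to 1300 nM.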

Compound 4, half-maximal inhibitory concentration: 190 nM
Compound 4: middle estimate off by 2.4-fold (0.37 log units), on the high side, and the stated range covers the measured number.
By their numbers in this assay, from the lowest: compounds 2, 4 and 1 (each within the scatter of the next, the first and the last beyond it). At a limit, above all of these: compound 3.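

On a sulfonamide nitrogen, 3-methylphenyl in place of 2-ethylphenyl gives, in this assay, a 1.8-fold lower number from compound 1 to compound 4 (0.27 log units; within the scatter). Going by these compounds alone, this is the first single-place change, and at this position the assay does not tell these two groups apart. No measurement shown accounts for this step. From the compounds shown here alone, compound 3 reads > 1000 nM, a limit and not a number, so the size of its gap stays unknown. Also open, going by these compounds, is how this position responds when the phenyl ring carries an amine or a carboxylic acid instead of an alkyl group.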